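A few compounds are considered here, and "the series" means these few. Any claim that something is new, unique, unknown or untested is made for them only; others in the source may bear on it.

Measured so far in an ADME assay on S9 fraction from liver (Homo sapiens) for metabolic stability, with a stated time of 1 h (on this read-out higher numbers stand for a more stable compound and lower numbers for a less stable compound), on the series:
Compound 1 `N#Cc1cnc(NCc2cnccc2C(F)(F)F)cc1N[C@H]1C[C@H](O)C1` gives 96%
Compound 2 `N#Cc1cnc(NCc2cnccc2C(F)(F)F)cc1NCCC1CCOCC1` gives 23%
Compound 3 `N#Cc1cnc(NCc2ccccc2C(F)(F)F)cc1N[C@H]1CC[C@@H](C(N)=O)CC1` gives 48%

Compound 3 stands second of the three, with its 48% under compound 1 and over compound 2. Compound 4 `N#Cc1cnc(NCc2cnccc2C(F)(F)F)cc1N[C@H]1CC[C@@H](C(N)=O)CC1` carries 4-(trifluoromethyl)pyridin-3-yl in place of 2-(trifluoromethyl)phenyl on a saturated chain carbon bound to a nitrogen on an aromatic ring. Among the compounds with values here, no measured step covers this swap. Within the data shown here, the one step at hand (a number 73 percentage points lower from compound 1 to compound 2 (beyond the scatter)) is large, but it puts 2-(oxan-4-yl)ethyl in place of 3-hydroxycyclobutyl, and both of its compounds already hold the entering group. That group therefore spans a wide range, and the midpoint of compound 1 (96%) and compound 2 (23%) lies only a little above compound 3. A small rise in this assay is expected, estimated as a number 12 percentage points higher from compound 3 to compound 4 (beyond the scatter) and possibly not beyond the scatter. Compound 4 is estimated at 60% (expected range 40% to 80%).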

Compound 4, percent of the compound remaining: 90%
The estimate for compound 4 lay 30 percentage points below the measured number; measured number above the stated range.
By their numbers in this assay, from the lowest: compound 2; then compound 3; then compounds 4 and 1 (each within the scatter of the next).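

In this assay, within the data shown here, the exchange of 2-(trifluoromethyl)phenyl for 4-(trifluoromethyl)pyridin-3-yl gives a number 42 percentage points higher from compound 3 to compound 4 (beyond the scatter) and is the first change read on a saturated chain carbon bound to a nitrogen on an aromatic ring. With 4-(trifluoromethyl)pyridin-3-yl held constant, the group on the nitrogen still separates the compounds unevenly, with a number 67 percentage points higher from compound 2 to compound 4 (beyond the scatter) against a number 6 percentage points lower from compound 1 to compound 4 (within the scatter) for the same entering 4-carbamoylcyclohexyl. Nothing at hand accounts for the size of either change.

From the compounds shown here alone, whether the same exchange gives a similar rise with 3-hydroxycyclobutyl or 2-(oxan-4-yl)ethyl on the nitrogen stays open. Also open, going by these compounds, is how this assay would read with a carboxylic acid or an amine in place of the carbamoyl on the cyclohexyl.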